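Benzothiazole for Benzimidazole on the Amine Nitrogen

The compounds below may be only part of what the source reports. "The series", "measured", "known", "first", "only" and "open" are said of these compounds alone.

Three compounds have been measured in an ADME assay on A549 cells (Homo sapiens) for cytotoxicity, read by CellTiter-Glo; a lower number here means that less compound is tolerated, a higher number that more compound is tolerated:
compound 1 `Cc1c(Cc2ccccc2)c(=O)oc2cc(OCC(O)CNCCCCCCO)ccc12` gives 40300 nM
compound 2 `Cc1c(Cc2ccccc2)c(=O)oc2cc(OCC(O)CNn3ccnn3)ccc12` gives > 100000 nM
compound 3 `Cc1c(Cc2ccccc2)c(=O)oc2cc(OCC(O)CNc3nc4ccccc4[nH]3)ccc12` gives > 100000 nM

For compound 3 the value is a limit, not a number. Compound 3 sits at the limit of > 100000 nM in this assay, at which 2 of the 3 values shown sit. Compound 4 `Cc1ccc2nc(NCC(O)COc3ccc4c(C)c(Cc5ccccc5)c(=O)oc4c3)sc2c1` differs from compound 3 by 6-methyl-1,3-benzothiazol-2-yl in place of 1H-benzimidazol-2-yl on an amine nitrogen. The measured steps that touch this amine nitrogen are an at least 2.4-fold higher number from compound 1 to compound 3 (0.39 log units; beyond the scatter) and a step that the two limits leave unreadable from compound 2 to compound 3, and neither reads an exchange of one fused two-ring group for another. Compound 4 is therefore expected to stay close to compound 3, a step of a number no higher from compound 3 to compound 4 (the limit leaves the size open), with a fair chance that only a limit is reported again. The estimate for compound 4 is 100000 nM, ranging from 30000 nM to 250000 nM.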

Compound 4, half-maximal cytotoxic concentration: > 100000 nM
Compound 4 gave a limit, no number; the forecaster's own chance of this, stated with the estimate: 55%; the middle value lies on the limit itself.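

In this assay compound 4 gives > 100000 nM, which is again a limit and not a number. The 6-methyl-1,3-benzothiazol-2-yl group, with sulfur and a methyl that 1H-benzimidazol-2-yl lacks, therefore behaves like the other groups that reach the limit, giving an at least 2.4-fold higher number from compound 1 to compound 4 (0.39 log units; beyond the scatter), while the steps from compound 2 and compound 3 to compound 4 cannot be read, since both ends are limits. Only the 6-hydroxyhexyl chain of compound 1 still yields a number: the limit of > 100000 nM in this assay, at which 3 of the 4 values shown sit.

From the compounds shown here alone, how far compound 2, compound 3 and compound 4 differ beyond the limit stays unknown. Going by these compounds, whether a shorter hydroxyalkyl chain or a simple phenyl ring on this nitrogen would give a number also stays open.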